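A Chloro Swap on the Benzyl Group of Compound 1

The compounds below may be only part of what the source reports. "The series", "measured", "known", "first", "only" and "open" are said of these compounds alone.

In a functional assay on HL-60 cells (Homo sapiens) for inhibition, read by CCK-8 assay, with a stated time of 48 h, tested at 20 uM (on this read-out higher numbers stand for more inhibition of growth at the one concentration tested and lower numbers for less inhibition of growth), compound 1 (`COc1ccc(Cc2nnc(NC(=O)/C(C#N)=C/c3ccccc3OS(=O)(=O)c3ccc(C)cc3)s2)cc1`) gives 25%, compound 2 (`COc1ccc(Cc2nnc(NC(=O)/C(C#N)=C/c3ccccc3OS(=O)(=O)c3ccccc3[N+](=O)[O-])s2)cc1`) gives 25% and compound 3 (`COc1ccc(Cc2nnc(NC(=O)/C(C#N)=C/c3ccccc3OS(=O)(=O)c3ccc(Cl)cc3)s2)cc1`) gives 20%, so compound 1 stands within the scatter of both others. Compound 4 (`Cc1ccc(S(=O)(=O)Oc2ccccc2/C=C(\C#N)C(=O)Nc2nnc(Cc3ccc(Cl)cc3)s2)cc1`) departs from compound 1 by chloro in place of methoxy on an aromatic carbon, turning 4-methoxybenzyl into 4-chlorobenzyl. The measured steps, no change at the digits printed from compound 1 to compound 2 (within the scatter), a number 5 percentage points lower from compound 1 to compound 3 (within the scatter) and a number 5 percentage points lower from compound 2 to compound 3 (within the scatter), all concern the group on the sulfonyl sulfur. None of them tests the benzyl group, so they offer only weak guidance, and no direction can be drawn from them. The expected step is no change at the digits printed from compound 1 to compound 4 (within the scatter), none beyond the scatter. Compound 4 is estimated at 25%, with an expected range from 10% to 45%.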

Compound 4, percent growth inhibition at one concentration: 15%
For compound 4 the middle estimate is 10 percentage points above the measured one, within the range that was stated.
By their numbers in this assay, from the lowest: compounds 4, 3, 1 and 2 (each within the scatter of the next).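

The first test of the benzyl group, chloro in place of methoxy, gives a number 10 percentage points lower from compound 1 to compound 4 (within the scatter) in this assay. This position, like the group on the sulfonyl sulfur, therefore shows no step beyond the scatter, though only this single swap at the position is shown. Nothing measured here offers an explanation for this step.

From the compounds shown here alone, it remains open whether 4-chlorobenzyl would give a similar number alongside the sulfonyl groups of compound 2 and compound 3. Also open, going by these compounds, is what an amine or a carboxylic acid in place of methoxy would give.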